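The source may report more compounds than this note shows. Statements on the series, on what has been measured and on what is new or still open speak of the compounds shown alone.

Compound 1 `COC(=O)N(C)C(C)C#CCn1ccnc1` and compound 3 `CN(C)C(=O)N(C)CC#CCn1ccnc1` share a terminal five-membered aromatic ring with 2 nitrogen; the difference between their two cores is not broken down here. In a functional assay on the whole organism for agonist activity, with Mus musculus as the target (a higher number here means that more compound is needed for the effect, a lower number that less compound is needed), compound 1 gives 6.6 mg/kg, and compound 3 gives 11.8 mg/kg. Compound 2 `COC(=O)N(C)C(C)C#CCn1cncc1C` carries the change methyl in place of hydrogen on an aromatic carbon on the core of compound 1, and in this assay compound 2 gives 97 mg/kg, so that a 15-fold higher number from compound 1 to compound 2 (1.17 log units; beyond the scatter). Compound 4 `Cc1cncn1CC#CCN(C)C(=O)N(C)C` carries the same change on the core of compound 3, namely (methyl in place of hydrogen on an aromatic carbon). Going by the values given here, because a 15-fold higher number from compound 1 to compound 2 (1.17 log units; beyond the scatter) is the only example of this change seen so far, a step of about the same size is expected, a 13-fold higher number from compound 3 to compound 4 (1.10 log units; beyond the scatter). On that basis compound 4 is estimated at 150 mg/kg in this assay, with a likely range from 50 mg/kg to 450 mg/kg.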

Compound 4, dose for half-maximal effect: 45.2 mg/kg
The estimate for compound 4 lay 3.3-fold (0.52 log units) above the measured number, and the stated range ends above it.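

In this assay the methyl in place of hydrogen on an aromatic carbon again gives a higher number, with a 3.8-fold higher number from compound 3 to compound 4 (0.58 log units; beyond the scatter), so the direction of the change carries over from the core of compound 1 to the core of compound 3. The size of the step does not carry over: the same change on two cores in this assay, a 15-fold higher number (1.17 log units; beyond the scatter) from compound 1 to compound 2 and a 3.8-fold higher number (0.58 log units; beyond the scatter) from compound 3 to compound 4, 3.8-fold (0.58 log units) apart, beyond the scatter of two such steps. These two pairs do not show which part of the cores sets the size of the step, since the cores differ in more than one place, and they cannot predict the step on a third core.

The compounds shown leave open how an ethyl group or a chlorine atom on the same ring carbon would compare with methyl. They also leave open whether a methyl on another ring carbon would give a similar step.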